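A few compounds are considered here, and "the series" means these few. Any claim that something is new, unique, unknown or untested is made for them only; others in the source may bear on it.

Working notes on the series. In an ADME assay on MCF10 cells (Homo sapiens) for cytotoxicity (a higher number here means a weaker inhibitor, a lower number a stronger inhibitor), compound 1 `CCc1nc(N)nc(N)c1C#CC(C)c1ccc(-c2ccccc2)cc1OC` gives "not determined" (no result reported), and compound 3 `CCc1nc(N)nc(N)c1C#CC(C)c1ccc(-c2ccc(C)cc2)cc1OC` gives "not determined" (no result reported), so neither carries a reported result. Within the data shown here, compound 2 `CCc1nc(N)nc(N)c1C#CC(C)c1ccc(-c2ccncc2)cc1OC` is the only member with a number: in this assay compound 2 gives 216000 nM. Among the measured compounds shown here, compound 2 therefore stands as the sole reference point, and no step between two measured compounds can be drawn from what is known.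

Compound 4 `CCc1nc(N)nc(N)c1C#CC(C)c1ccc(-c2ccc(F)cc2)cc1OC` remains to be measured in this assay. It differs from compound 2 in a single place: 4-fluorophenyl in place of pyridin-4-yl on an aromatic carbon. The exchange sits on an aromatic carbon of a six-membered aromatic ring of carbon only, meta to a methoxy group and para to a large group.

For the measured compounds named here, with one measured value and no measured step, there is no basis for expecting a direction. The step from compound 2 to compound 4 is expected to stay within the scatter, a 1.1-fold lower number from compound 2 to compound 4 (0.03 log units; within the scatter). In this assay compound 4 is expected to give about 200000 nM, with a range from 70000 nM to 600000 nM. A report of only a limit rather than a number for compound 4 would not be surprising.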

Compound 4, half-maximal inhibitory concentration: 60000 nM
For compound 4 the middle estimate is 3.3-fold (0.52 log units) above the measured one, and the stated range ends above it.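

In this assay, among these compounds, 4-fluorophenyl in place of pyridin-4-yl gives a 3.6-fold lower number from compound 2 to compound 4 (0.56 log units; beyond the scatter), the first readable step and one that lies beyond the scatter, so the number does respond to the group at this aromatic carbon, para to a large group. Steps involving compound 1 or compound 3 cannot be read, so this single exchange is the only view of the position and supports no trend across the groups shown. Nothing available bears on the cause of this step.

On these data alone, with the step resting on one pair, it stays open whether the change in the number follows the loss of the ring nitrogen, the arrival of the fluorine, or both. As far as these compounds go, it is also open how the number would respond at this position to a group of another kind, such as a carboxylic acid or an aminomethyl group.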